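A few compounds are considered here, and "the series" means these few. Any claim that something is new, unique, unknown or untested is made for them only; others in the source may bear on it.

Measured so far in a functional assay on Hs-578T cells (Homo sapiens) for inhibition, read by sulforhodamine B assay, with a stated time of 48 h, tested at 10 uM; a lower number here means less inhibition, a higher number more inhibition at the concentration tested (going by the name of the read-out):
compound 1 `Fc1ccc(-c2cn3ccnc3c(-c3ccc4ncn(C5CCCCC5)c4c3)n2)cc1` gives 17.6%
compound 2 `Clc1ccc(-c2cn3ccnc3c(-c3ccc4ncn(C5CCCCC5)c4c3)n2)cc1` gives 6.35%
compound 3 `Brc1ccc(-c2cn3ccnc3c(-c3ccc4ncn(C5CCCCC5)c4c3)n2)cc1` gives 24.5%

Compound 3 holds the highest of the three numbers in this assay, but its standing is thin: the gap to compound 1 is within the scatter, a number 6.9 percentage points higher from compound 1 to compound 3 (within the scatter), and only the gap to compound 2 is beyond it, a number 18.2 percentage points higher from compound 2 to compound 3 (beyond the scatter). Within the data shown here, the whole series so far varies the halogen at one place on the phenyl and stays within a narrow band: a number 11.3 percentage points lower from compound 1 to compound 2 (beyond the scatter) is the largest downward move, and none of the three compounds rises far above the lowest.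

Compound 4 `COc1ccccc1-c1cn2ccnc2c(-c2ccc3ncn(C4CCCCC4)c3c2)n1` takes a different route: 2-methoxyphenyl in place of 4-bromophenyl on an aromatic carbon. Among the measured compounds shown here, no measured step swaps a halogen for a methoxy or shifts the substituent to a different position on the phenyl, so the three halogen steps bear on it only as a gauge of how much this position moves the read-out, which is modest. On that basis a change no larger than the scatter is expected, with a slight lean downward because compound 2 already shows 6.35% at the same place; the expected step is a number 9.5 percentage points lower from compound 3 to compound 4 (within the scatter). For compound 4 the estimate in this assay is 15%, with a range from 0% to 35%.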

Compound 4, a percentage reported as inhibition, at one concentration (the size of the read-out at that concentration, not a potency): 15.8%
The estimate for compound 4 lay 0.8 percentage points below the measured number, and the stated range covers the measured number.
By their numbers in this assay, from the lowest: compounds 2, 4, 1 and 3 (each within the scatter of the next, the first and the last beyond it).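

In this assay, 2-methoxyphenyl at this aromatic carbon does not separate from any of the three halophenyl compounds, with a number 8.7 percentage points lower from compound 3 to compound 4 (within the scatter) and a number 9.5 percentage points higher from compound 2 to compound 4 (within the scatter) and a number 1.8 percentage points lower from compound 1 to compound 4 (within the scatter). Among these compounds, this change replaces the halogen with a methoxy group, moves the substituent to a different place on the phenyl and brings in 1 hydrogen-bond acceptor, yet the only steps beyond the scatter at this position remain the two among the halogens, a number 11.3 percentage points lower from compound 1 to compound 2 (beyond the scatter) and a number 18.2 percentage points higher from compound 2 to compound 3 (beyond the scatter). No measurement at hand bears on the reason for these numbers.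

Since the group and its place on the phenyl change together here, the contribution of each remains unresolved, and 4-methoxyphenyl would be the compound to separate them. As far as these compounds go, it also remains open whether a phenyl carrying a dimethylamino group or a carboxylic acid, or a replacement of the cyclohexyl group shared by all four compounds, would move the read-out well beyond the narrow band seen so far.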